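Swapping Bromine for Chlorine on the Shared Core

The source may report more compounds than this note shows. Statements on the series, on what has been measured and on what is new or still open speak of the compounds shown alone.

Measured compounds:
- compound 1, `COc1cc(-c2cc(-c3ccc(N)cc3)nc(-c3ccccc3)n2)cc(OC)c1OC`, in a functional assay on HT-29 cells (Homo sapiens) for inhibition, read by MTT assay, with a stated time of 48 h (a higher number here means a weaker inhibitor, a lower number a stronger inhibitor), compound 1 gives > 25000 nM, which is a limit of the assay rather than a number.
- compound 2, `COc1cc(-c2cc(-c3ccc(Br)cc3)nc(-c3ccccc3)n2)cc(OC)c1OC`, in this assay compound 2 gives 3170 nM.
- compound 3, `COc1cc(-c2cc(-c3cccc4ccccc34)nc(-c3ccccc3)n2)cc(OC)c1OC`, in this assay compound 3 gives 4730 nM.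

Compound 2 has the lowest of the two real numbers, but compound 3 sits within the scatter of it, so no order between the two can be claimed. The step of an at least 7.8-fold lower number from compound 1 to compound 2 (0.89 log units; beyond the scatter) shows that bromo in place of amino gives a clearly lower number, and an at least 5.2-fold lower number from compound 1 to compound 3 (0.72 log units; beyond the scatter) shows a similar move; the step of a 1.5-fold higher number from compound 2 to compound 3 (0.17 log units; within the scatter) stays within the scatter.

Compound 4, `COc1cc(-c2cc(-c3ccc(Cl)cc3)nc(-c3ccccc3)n2)cc(OC)c1OC`, has not been measured. It differs from compound 2 as follows: chloro in place of bromo on an aromatic carbon. Among the compounds with values here, no measured step swaps one halogen for another, so the closest guide is that compound 2 already carries a halogen at this place. The exchange is small, and the expected step of a 1.4-fold higher number from compound 2 to compound 4 (0.15 log units; within the scatter) is therefore within the scatter, leaning slightly toward a higher number. For compound 4 the estimate in this assay is 4500 nM, with a range from 1800 nM to 12000 nM.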

Compound 4, half-maximal inhibitory concentration: 6230 nM
Beside the measured number, compound 4's estimate is 1.4-fold (0.14 log units) below it, and the stated range covers the measured number.
By their numbers in this assay, from the lowest: compounds 2, 3 and 4 (each within the scatter of the next). At a limit, above all of these: compound 1.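

In this assay, exchanging one halogen for another on this aromatic carbon, para to a large group, gives a 2.0-fold higher number from compound 2 to compound 4 (0.29 log units; within the scatter), so bromo and chloro cannot be told apart here. The 4-chlorophenyl and naphthalen-1-yl groups cannot be ordered either, with a 1.3-fold higher number from compound 3 to compound 4 (0.12 log units; within the scatter). A second halogen in place of amino also gives a step beyond the scatter, an at least 4.0-fold lower number from compound 1 to compound 4 (0.60 log units; beyond the scatter), but compound 1 stands at a limit, so this step gives only a bound on the size of the change: the limit of > 25000 nM in this assay, at which 1 of the 4 values shown sits.

The compounds shown leave open how fluoro or iodo would read at this place, and whether a methoxy group or a carboxylic acid would fall with the halogens or with amino. Going by these compounds, how far the true number for compound 1 lies past its limit also remains open.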